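Swapping the amine on a chromone dithiocarbamate-type thiocarbonyl

A few compounds are considered here, and "the series" means these few. Any claim that something is new, unique, unknown or untested is made for them only; others in the source may bear on it.

Measured compounds:
- compound 1, `O=c1c(CSC(=S)N2CCOCC2)coc2cc(Cl)ccc12`: 900 nM
- compound 2, `CC(C)N(C(=S)SCc1coc2ccccc2c1=O)C(C)C`: 3000 nM
- compound 3, `O=c1c(CSC(=S)N2CCOCC2)coc2ccccc12`: 4400 nM

In a functional assay on HEp-2 cells (Homo sapiens) for antiproliferative activity, read by MTT assay, with a stated time of 72 h (on this read-out lower numbers stand for stronger inhibition and higher numbers for weaker inhibition), compound 3 gives the highest number of the three. Its nearest neighbour is compound 2, where the change is a 1.5-fold higher number from compound 2 to compound 3 (0.17 log units; within the scatter). The furthest is compound 1, where the change is a 4.9-fold higher number from compound 1 to compound 3 (0.69 log units; beyond the scatter).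

Compound 4, `CN1CCN(C(=S)SCc2coc3ccccc3c2=O)CC1`, differs from compound 3 only on the thiocarbonyl carbon: 4-methylpiperazin-1-yl in place of morpholin-4-yl on a thiocarbonyl carbon. Going by the values given here, of the measured steps, only the one from compound 2 to compound 3 bears on this change, since it too alters the amine attached to the thiocarbonyl carbon, and that step stayed within the scatter. The step from compound 1 to compound 3 concerns the aromatic chloro and says nothing about the amine. On this basis the amine part looks tolerant to exchange among the cases shown, and no step beyond the scatter is expected in this assay for compound 4; the expected move from compound 3 is a 1.1-fold lower number from compound 3 to compound 4 (0.04 log units; within the scatter). Compound 4 is therefore estimated at 4000 nM, with a range from 1500 nM to 12000 nM.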

Compound 4, half-maximal inhibitory concentration: 2400 nM
Compound 4: middle estimate off by 1.7-fold (0.22 log units), on the high side; measured number inside the range.
By their numbers in this assay, from the lowest: compound 1; then compounds 4, 2 and 3 (each within the scatter of the next).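

In this assay, the new amine on the thiocarbonyl carbon falls within the scatter of both earlier amines, as shown by the exchange of morpholin-4-yl for 4-methylpiperazin-1-yl (a 1.8-fold lower number from compound 3 to compound 4 (0.26 log units; within the scatter)) and of diisopropylamino for the same group (a 1.3-fold lower number from compound 2 to compound 4 (0.10 log units; within the scatter)). Where compound 2 and compound 3 offered a single comparison at this position, compound 4 adds a third amine, with a second ring nitrogen carrying a methyl group where morpholin-4-yl has its ring oxygen, and the read-out still does not separate the three, so among these compounds the only step beyond the scatter remains the one at the aromatic chloro. Nothing available explains why these amines read alike.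

The compounds shown leave open whether an amine with no second ring hetero atom, such as piperidin-1-yl, or one with a free carboxylic acid on its ring would also stay within the scatter. They also leave open whether the aromatic chloro of compound 1 would give a similar step when paired with 4-methylpiperazin-1-yl or diisopropylamino.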